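The compounds below may be only part of what the source reports. "The series", "measured", "known", "first", "only" and "open" are said of these compounds alone.

Compound 1 `Cc1cc(C)cc(COc2ccc(-c3cc(CN4CCN(Cc5ccc(C(F)(F)F)cc5)CC4)no3)cc2)c1` gives 1600 nM in a functional assay on MCF7 cells (Homo sapiens) for antiproliferative activity, read by sulforhodamine B assay, with a stated time of 72 h (on this read-out higher numbers stand for weaker inhibition and lower numbers for stronger inhibition), the lower of the two numbers in hand, though the gap to compound 2 is within the scatter. Compound 2 `Fc1ccccc1COc1ccc(-c2cc(CN3CCN(Cc4ccc(C(F)(F)F)cc4)CC3)no2)cc1`, with 2-fluorophenyl in place of 3,5-dimethylphenyl on a saturated chain carbon bound to an oxygen on an aromatic ring, gives 3000 nM in this assay; that step is a 1.9-fold higher number from compound 1 to compound 2 (0.27 log units; within the scatter). Compound 3 `Fc1ccc(COc2ccc(-c3cc(CN4CCN(Cc5ccc(C(F)(F)F)cc5)CC4)no3)cc2)cc1` carries the change (4-fluorophenyl in place of 3,5-dimethylphenyl on a saturated chain carbon bound to an oxygen on an aromatic ring). Among the compounds with values here, the one comparable step, from compound 1 to compound 2, stayed within the scatter, so no shift beyond the scatter is expected in this assay for compound 3, at most a small rise. The expected step from compound 1 is a 1.6-fold higher number from compound 1 to compound 3 (0.19 log units; within the scatter). Compound 3 is estimated at 2500 nM, range 1200 nM to 5500 nM.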

Compound 3, half-maximal inhibitory concentration: 7900 nM
Compound 3: middle estimate off by 3.2-fold (0.50 log units), on the low side; measured number above the stated range.
By their numbers in this assay, from the lowest: compounds 1 and 2 (each within the scatter of the next); then compound 3.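

In this assay, 4-fluorophenyl in place of 3,5-dimethylphenyl on this saturated chain carbon gives a 4.9-fold higher number from compound 1 to compound 3 (0.69 log units; beyond the scatter), so this place can respond beyond the scatter, which the 2-fluorophenyl change did not show. Moving between the two fluorophenyl groups also counts, with a 2.6-fold higher number from compound 2 to compound 3 (0.42 log units; beyond the scatter), so the site of the fluorine on the ring matters here, not merely its presence. Nothing in hand bears on the reason for these steps. The compounds shown leave open where 3-fluorophenyl, unsubstituted phenyl or 4-methoxyphenyl would fall at this place, and whether any of them would read lower than compound 1.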